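A few compounds are considered here, and "the series" means these few. Any claim that something is new, unique, unknown or untested is made for them only; others in the source may bear on it.

In an ADME assay on CCRF-CEM cells (Homo sapiens) for cytotoxicity, read by MTT assay, with a stated time of 5 days (on this read-out higher numbers stand for lower toxicity in this test and lower numbers for higher toxicity in this test), compound 3 `COc1cc(Cc2cnc(/N=C3\C(=O)N(CN4CCN(c5ccccn5)CC4)c4ccc(Cl)cc43)nc2N)cc(OC)c1OC` gives 29.4 ug/mL, the lowest of the two numbers recorded there. Its nearest neighbour is compound 2 `COc1cc(Cc2cnc(/N=C3\C(=O)N(CN4CCN(C)CC4)c4ccc(Cl)cc43)nc2N)cc(OC)c1OC`, which in this assay gives 88 ug/mL; the step of a 3.0-fold lower number from compound 2 to compound 3 (0.48 log units; beyond the scatter) arises from placing pyridin-2-yl in place of methyl on an amine nitrogen in a ring. Compound 1 `CCCCN(CCCC)CN1C(=O)/C(=N\c2ncc(Cc3cc(OC)c(OC)c(OC)c3)c(N)n2)c2cc(Cl)ccc21`, carrying a dibutylamino group at the same position, is recorded as "not determined" (no result reported) in this assay, so no result is reported for it there.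

The step to compound 4 `CCN(CC)CN1C(=O)/C(=N\c2ncc(Cc3cc(OC)c(OC)c(OC)c3)c(N)n2)c2cc(Cl)ccc21` is diethylamino in place of 4-(pyridin-2-yl)piperazin-1-yl on a saturated chain carbon bound to an amide-type nitrogen in a ring. Among the measured compounds shown here, only the step from compound 2 to compound 3 bears on it, and only in part: it shows that the pyridin-2-yl group lowers the number, whereas compound 4 drops the whole ring system in favour of an open-chain amine. Removing the pyridin-2-yl group is therefore expected to move the number back toward that of compound 2, with a step of a 2.0-fold higher number from compound 3 to compound 4 (0.31 log units; beyond the scatter) expected in this assay. Compound 4 is estimated at 60 ug/mL in this assay, with a range from 25 ug/mL to 140 ug/mL.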

Compound 4, half-maximal cytotoxic concentration: 98.4 ug/mL
Compound 4: the middle estimate sits 1.6-fold (0.21 log units) below what was measured; measured number inside the range.
By their numbers in this assay, from the lowest: compound 3; then compounds 2 and 4 (each within the scatter of the next).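

Exchanging 4-(pyridin-2-yl)piperazin-1-yl for diethylamino on the saturated chain carbon gives a 3.3-fold higher number from compound 3 to compound 4 (0.52 log units; beyond the scatter) in this assay, so a low number is not common to every amine at this position. Diethylamino in place of 4-methylpiperazin-1-yl gives a 1.1-fold higher number from compound 2 to compound 4 (0.05 log units; within the scatter), which shows that this open-chain amine and the methyl-bearing ring cannot be told apart here, while compound 3 stands apart from both. No experimental evidence is at hand to explain this difference.

The compounds shown leave open whether a phenyl group on the piperazine ring would go with a number like that of compound 3. They also leave open whether a ring amine such as morpholine would fall with compound 2 and compound 4.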